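The compounds below may be only part of what the source reports. "The series", "measured", "known", "first", "only" and "open" are said of these compounds alone.

Within the data shown here, compound 2, `Cc1ccc([C@H](C)NC(=O)c2ccc(Sc3ccc(N)cc3)c(Nc3ncnc4nc(C(C)C)ccc34)c2)cc1`, is one of two compounds measured in an ADME assay on the whole organism (strain Sprague-Dawley) for metabolic stability, with Rattus norvegicus as the target, at a dose of 5 mg/kg by the oral route; a higher number here means that the compound lasts longer, a lower number that the compound disappears faster; compound 2 gives 2.6 h. Among the measured compounds shown here, its only companion is compound 1, `CC(C)c1ccc2c(Nc3cc(C(=O)N[C@@](C)(CO)c4ccccc4)ccc3Sc3ccc(N)cc3)ncnc2n1`, which in this assay gives 2.7 h. For the measured compounds named here, the single step between them, a 1.0-fold lower number from compound 1 to compound 2 (0.02 log units; within the scatter), shows that exchanging the group on the amide-type nitrogen left the half-life essentially unchanged.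

Compound 3, `CC(C)c1ccc2c(Nc3cc(C(=O)N[C@@H](C)C4CCCCC4)ccc3Sc3ccc(N)cc3)ncnc2n1`, has not yet been measured in this assay. It differs from compound 2 in one place: cyclohexyl in place of 4-methylphenyl on a saturated chain carbon bound to an amide-type nitrogen and a saturated chain carbon. Going by the values given here, the only comparison available, the step from compound 1 to compound 2, concerns the same position and stayed within the scatter, so no clear movement in either direction is expected for a further swap there. The expected step is therefore no change at the digits printed from compound 2 to compound 3 (within the scatter), and compound 3 is estimated to give 2.6 h, with a range from 1.3 h to 5.2 h.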

Compound 3, half-life: 0.8 h
Compound 3: middle estimate off by 3.3-fold (0.51 log units), on the high side; measured number below the stated range.
By their numbers in this assay, from the lowest: compound 3; then compounds 2 and 1 (each within the scatter of the next).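

At this position the ring is not indifferent: in this assay, cyclohexyl in place of 4-methylphenyl gives a 3.3-fold lower number from compound 2 to compound 3 (0.51 log units; beyond the scatter), whereas the earlier exchange there stayed within the scatter. The change of 1-(hydroxymethyl)-1-phenylethyl to 1-cyclohexylethyl points the same way, with a 3.4-fold lower number from compound 1 to compound 3 (0.53 log units; beyond the scatter), so among these three compounds the two with a six-membered aromatic ring on this side last longer than the one with a non-aromatic ring. No measurement shown gives a reason for this drop.

Among these compounds, the single swap also removes the methyl on the ring, so the effect of the ring itself cannot be separated from that of the methyl. A plain 1-phenylethyl group, or a cyclohexyl ring bearing a hydroxyl group, would be needed to separate such questions and to show whether the half-life can be recovered without an aromatic ring.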